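A Shorter Tail on the Shared Core

The source may hold more compounds than are shown below. What is called first, only, known or untested is meant among the compounds shown, and "the series" means these compounds.

Compound 2 `COc1cc(Cl)cc(-c2nn(-c3cccc(NC(=O)Nc4ccc(Cl)c(C(F)(F)F)c4)c3)cc2-c2ccncc2)c1` was tested in a functional assay on HCT-15 cells (Homo sapiens) for inhibition, read by sulforhodamine B assay, with a stated time of 48 h, tested at 1 uM (a lower number here means a stronger effect, a higher number a weaker effect of the compound at the concentration tested), where compound 2 gives 35%. Among the three numbers shown this is the second highest: compound 1 `O=C(Nc1cccc(-n2cc(-c3ccncc3)c(-c3cc(O)cc(Cl)c3)n2)c1)Nc1ccc(Cl)c(C(F)(F)F)c1` gives 90%, and compound 3 `COc1cc(Cl)cc(-c2nn(-c3cccc(NC(=O)Nc4cc(C(F)(F)F)cc(C(F)(F)F)c4)c3)cc2-c2ccncc2)c1` gives 17%. Within the data shown here, the one measured step, a number 55 percentage points lower from compound 1 to compound 2 (beyond the scatter), concerns the methyl on the oxygen; compound 3 differs from compound 2 in another place, and no step between them is given. Compound 4 `COc1cc(Cl)cc(-c2nn(-c3cccc(NC(=O)c4cccc(C(F)(F)F)c4)c3)cc2-c2ccncc2)c1` differs from compound 2 by 3-(trifluoromethyl)phenyl in place of (4-chloro-3-(trifluoromethyl)phenyl)amino on a carbonyl carbon. Among the measured compounds shown here, no measured step touches that change, so the data give neither its direction nor its size. Compound 4 is therefore expected to give roughly 50%, somewhere between 20% and 85%. For the measured compounds named here, the expected step of a number 15 percentage points higher from compound 2 to compound 4 (beyond the scatter) rests on no measured precedent.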

Compound 4, a percentage reported as activity, at one concentration (the size of the read-out at that concentration, not a potency): 71%
For compound 4 the middle estimate is 21 percentage points below the measured one; the measured number falls inside the stated range.
By their numbers in this assay, from the lowest: compound 3; then compound 2; then compound 4; then compound 1.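

The group on the carbonyl carbon matters as much as the methyl on the oxygen: swapping (4-chloro-3-(trifluoromethyl)phenyl)amino for 3-(trifluoromethyl)phenyl in this assay gives a number 36 percentage points higher from compound 2 to compound 4 (beyond the scatter), a clear loss of effect. This one swap removes both the amino nitrogen with its hydrogen and the chlorine, so the step cannot be credited to either alone. Nothing measured here explains why the effect falls. The compounds shown leave open which of those two losses counts. They also leave open how a carboxylic acid or a morpholine on that carbonyl carbon would behave.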